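This account rests on a few compounds, and the source may have more. Where it says the series, first, only, none or still open, it means among the compounds named here.

Measured so far:
Compound 1 `NCC(N)C(=O)NCc1ccccc1`: in a functional assay on the whole organism (strain NMRI) with Mus musculus as the target, in the maximal electroshock model, with a stated time of 30 min (on this read-out higher numbers stand for an effect only at larger amounts of compound and lower numbers for an effect already at smaller amounts), compound 1 gives > 68 mg/kg, which is a limit of the assay.
Compound 2 `N[C@H](CCO)C(=O)NCc1ccccc1`: in this assay compound 2 gives > 160 mg/kg, again a limit.

Compound 1 thus stands only at a limit, and the step that the two limits leave unreadable from compound 1 to compound 2 is unreadable, since both values sit at limits (the limit of > 160 mg/kg in this assay, at which 1 of the 2 values shown sits, (the limit of > 68 mg/kg in this assay, at which 1 of the 2 values shown sits)). Compound 3 `CN(C)CC(N)C(=O)NCc1ccccc1` differs from compound 1 by dimethylamino in place of amino on a saturated chain carbon, two bonds along the chain from an amine nitrogen and a carbonyl carbon. Among the compounds with values here, no measured step bears on this change, so no direction can be expected beyond the scatter. The estimate for compound 3 in this assay is a step that the limit leaves unreadable from compound 1 to compound 3, giving 100 mg/kg with a range from 30 mg/kg to 300 mg/kg.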

Compound 3, dose for half-maximal effect: 94 mg/kg
Beside the measured number, compound 3's estimate is 1.1-fold (0.03 log units) above it; the measured number falls inside the stated range.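

Compound 1 stands only at a limit of the assay, and the step from it to compound 3 cannot be read. The compounds shown leave open what dimethylamino in place of amino does in this assay when set against a firm number for compound 1.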